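Methyl in Place of Methoxy: What Compound 4 Should Show

The source may hold more compounds than are shown below. What is called first, only, known or untested is meant among the compounds shown, and "the series" means these compounds.

Three compounds share one core. For the measured compounds named here, in a functional assay on HL-60 cells (Homo sapiens) for cytotoxicity, read by luminescence and CellTiter-Glo, with a stated time of 3 days (on this read-out lower numbers stand for stronger inhibition and higher numbers for weaker inhibition), compound 1 `N#Cc1ccc(NC(=O)c2ccc(-c3cccnc3)cc2O)cc1` gives 6660 nM, and compound 2 `N#Cc1ccc(NC(=O)c2ccc(Br)cc2O)cc1` gives 1210 nM; the only measured step is a 5.5-fold lower number from compound 1 to compound 2 (0.74 log units; beyond the scatter). Compound 3 `COc1cccc(C(=O)Nc2ccc(C#N)cc2)c1O` reaches only a limit of this assay, > 10000 nM, which is the limit of > 10000 nM in this assay, at which 1 of the 3 values shown sits. Compound 4 `Cc1cccc(C(=O)Nc2ccc(C#N)cc2)c1O` differs from compound 3 by methyl in place of methoxy on an aromatic carbon. Going by the values given here, the single measured step concerns a different group at another place on the shared core, so no measured step bears directly on this change. A small step, with no direction beyond the scatter, is therefore expected, starting from a limit. Compound 4 is expected to give about 12000 nM, with a range from 4000 nM to 40000 nM, so the expected step is a step that the limit leaves unreadable from compound 3 to compound 4.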

Compound 4, half-maximal inhibitory concentration: > 10000 nM
Compound 4: a limit, no number; the forecaster's own chance of this, stated with the estimate: 60%; the middle value does not contradict the limit.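

No step from compound 3 to compound 4 can be read, since both stand at a limit in this assay: the limit of > 10000 nM in this assay, at which 2 of the 4 values shown sit.

The compounds shown leave open whether methyl in place of methoxy changes the value at all.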